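This account rests on a few compounds, and the source may have more. Where it says the series, first, only, none or still open, it means among the compounds named here.

Values so far in a physicochemical assay for lipophilicity, measured as octanol-water partition; on this read-out lower numbers stand for lower lipophilicity and higher numbers for higher lipophilicity

compound 1 (`COc1ccccc1C(=O)O[C@@H]1C[C@H](C)CC[C@H]1C(C)C`) gives 4.57
compound 2 (`CC(C)[C@@H]1CC[C@@H](C)C[C@H]1OC(=O)c1ccccc1`) gives 4.82
compound 3 (`CC(C)[C@@H]1CC[C@@H](C)C[C@H]1OC(=O)c1ccccc1Cl`) gives 5.34

Of these three, compound 3 stands highest at 5.34 in this assay. Two measured steps lead to it: a number 0.52 log units higher from compound 2 to compound 3 (beyond the scatter) and a number 0.77 log units higher from compound 1 to compound 3 (beyond the scatter). The remaining step, a number 0.25 log units higher from compound 1 to compound 2 (within the scatter), separates the other two.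

The next compound is compound 4 (`CC(C)[C@@H]1CC[C@@H](C)C[C@H]1OC(=O)c1ccccc1Br`). The change is bromo in place of chloro on an aromatic carbon, ortho to a large group.

Going by the values given here, no measured step exchanges one halogen for another, so the guide is indirect. The closest one is a number 0.52 log units higher from compound 2 to compound 3 (beyond the scatter), where chloro replaces hydrogen at the same place. The step with methoxy leaving, a number 0.77 log units higher from compound 1 to compound 3 (beyond the scatter), bears on it less directly. Here one halogen merely replaces another, so a step smaller than either of these is expected, pointing upward and possibly not clearing the scatter. The expected step is a number 0.14 log units higher from compound 3 to compound 4 (within the scatter) in this assay.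

For compound 4 the estimated value is 5.48, with an expected range from 5.2 to 5.8.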

Compound 4, partition coefficient: 5.61
Compound 4: the middle estimate sits 0.13 log units below what was measured, and the stated range covers the measured number.
By their numbers in this assay, from the lowest: compounds 1 and 2 (each within the scatter of the next); then compounds 3 and 4 (each within the scatter of the next).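

In this assay, going by these compounds alone, the exchange of chloro for bromo on this aromatic carbon, ortho to a large group, gives the first direct comparison of two halogens at this place: a number 0.27 log units higher from compound 3 to compound 4 (within the scatter) leaves the two compounds unresolved, so the series does not separate these halogens. Within the data shown here, measured against the other two substituents, bromo gives a number 0.79 log units higher from compound 2 to compound 4 (beyond the scatter) and a number 1.04 log units higher from compound 1 to compound 4 (beyond the scatter) and the second of these is the only large step, so the two halogen compounds stand clear of the hydrogen and methoxy compounds as a pair, while compound 1 and compound 2 remain within the scatter of each other. Nothing measured bears on the reason for these steps.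

The compounds shown leave open how fluoro, iodo or trifluoromethyl would sit relative to chloro and bromo at this place, and whether an amine or a carboxylic acid there would fall outside the range seen so far. They also leave open whether the exchange of chloro for bromo would give a similar result on any other carbon of the aromatic ring.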